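The compounds below may be only part of what the source reports. "The series", "measured", "known", "first", "only" and "open" are said of these compounds alone.

In an assay on isolated protein for inhibition of Rho-associated protein kinase 2 (Homo sapiens), read by radiometric assay (a lower number here means a stronger inhibitor, a higher number a weaker inhibitor), compound 3 `NCc1ccc(C(=O)Nc2ccncc2)cc1-c1cccc(C(=O)OCC2CCCC2)c1` gives 5 nM, the lowest of the three numbers. Compound 2 `COC(=O)c1cccc(-c2cc(C(=O)Nc3ccncc3F)ccc2CN)c1` gives 7.8 nM, which lies within the scatter of compound 3, while compound 1 `NCc1ccc(C(=O)Nc2ccncc2)cc1-c1cccc(C(=O)OCC2CCCCC2)c1` gives 48 nM, beyond it. Among the compounds with values here, the single measured step, a 9.6-fold lower number from compound 1 to compound 3 (0.98 log units; beyond the scatter), is modest. Compound 4 `COC(=O)c1cccc(-c2cc(C(=O)Nc3ccncc3)ccc2CN)c1` differs from compound 3 by hydrogen in place of cyclopentyl on a saturated chain carbon bound to an oxygen next to a carbonyl group. Within the data shown here, no measured step replaces the cyclopentyl with hydrogen; the closest guide is compound 2, which gives 7.8 nM within the scatter of compound 3 and carries the same methoxycarbonyl group as compound 4. Compound 4 is therefore expected to move little, a 1.6-fold higher number from compound 3 to compound 4 (0.20 log units; within the scatter), with an estimated 8 nM and a range from 3 nM to 25 nM.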

Compound 4, half-maximal inhibitory concentration: 2.9 nM
For compound 4 the middle estimate is 2.8-fold (0.44 log units) above the measured one; the measured number lies below the stated range.
By their numbers in this assay, from the lowest: compounds 4, 3 and 2 (each within the scatter of the next, the first and the last beyond it); then compound 1.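

Cutting the cyclopentyl back to leave methoxycarbonyl does not separate the two esters (a 1.7-fold lower number from compound 3 to compound 4 (0.24 log units; within the scatter)), whereas the same cut from the cyclohexyl ester does (a 17-fold lower number from compound 1 to compound 4 (1.22 log units; beyond the scatter)). At this place, then, the lost number belongs to the cyclohexyl alone among the groups shown, and the cyclopentyl shows no gain over plain methyl. Within the data shown here, on the aromatic carbon, hydrogen in place of fluoro gives the first reading at that place (a 2.7-fold lower number from compound 2 to compound 4 (0.43 log units; beyond the scatter)).

As far as these compounds go, whether an ethyl group, a longer chain or a carboxylic acid would hold the number at the ester stays open. Nothing measured here gives a reason for these differences.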